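Naphthalen-1-yl to thiophen-2-yl on the shared core

The source may hold more compounds than are shown below. What is called first, only, known or untested is meant among the compounds shown, and "the series" means these compounds.

Within the data shown here, in a functional assay on COLO 205 cells (Homo sapiens) for cytotoxicity, read by sulforhodamine B assay, with a stated time of 48 h (a higher number here means a weaker inhibitor, a lower number a stronger inhibitor), compound 1 (`COc1cc(/C=C/C(=O)/C=C/c2cccc3ccccc23)ccc1OCc1cn(CCOc2cc(=O)oc3ccccc23)nn1`) gives 9950 nM as one of only two numbers available so far. The other comes from compound 2 (`COc1cc(/C=C/C(=O)/C=C/c2cccc3ccccc23)ccc1OCc1cn(CCCOc2cc(=O)oc3ccccc23)nn1`) at 12700 nM and the two values lie within the usual scatter of each other, so no order can be drawn between them.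

Compound 3 (`COc1cc(/C=C/C(=O)/C=C/c2cccs2)ccc1OCc1cn(CCOc2cc(=O)oc3ccccc23)nn1`) has not yet been measured. The change from compound 1 to compound 3 is thiophen-2-yl in place of naphthalen-1-yl on a double-bonded chain carbon bound to a double-bonded chain carbon and it puts thiophen-2-yl in place of naphthalen-1-yl on a double-bonded chain carbon bound to a double-bonded chain carbon.

Among the measured compounds shown here, no measured pair shows what such an exchange does, so the expectation has little to rest on. In this assay, for the measured compounds named here, a small move toward a higher number is expected, about the size of the scatter or only slightly beyond it, with no large step. The expected size is a 1.3-fold higher number from compound 1 to compound 3 (0.12 log units; within the scatter) as a working estimate. For compound 3 the estimated value is 13000 nM with an expected range from 5500 nM to 30000 nM in this read-out.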

Compound 3, half-maximal inhibitory concentration: 11400 nM
Estimate against measurement, compound 3: 1.1-fold (0.06 log units) above; low and high end bracket the measured number.
By their numbers in this assay, from the lowest: compounds 1, 3 and 2 (each within the scatter of the next).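

In this assay, among these compounds, thiophen-2-yl in place of naphthalen-1-yl on a double-bonded chain carbon bound to a double-bonded chain carbon gives a 1.1-fold higher number from compound 1 to compound 3 (0.06 log units; within the scatter), the first step that can be read at this position. Here, a group of 10 heavy atoms with 2 six-membered aromatic rings of carbon only gives way to one of 5 heavy atoms with one five-membered aromatic ring and 1 hydrogen-bond acceptor, and the two numbers still cannot be told apart in this read-out. Nothing available on these compounds speaks to the reason for this outcome.

A single exchange at this place cannot show whether the same holds for other groups, such as a plain phenyl, an amine or a carboxylic acid, or whether any of them would move the number beyond the scatter. As far as these compounds go, it is also open whether thiophen-2-yl reads the same way on the core of compound 2, with its longer chain, since only the core of compound 1 carries this step.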